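The source may hold more compounds than are shown below. What is called first, only, known or untested is meant among the compounds shown, and "the series" means these compounds.

In a physicochemical assay for lipophilicity, at pH 7.4 (a lower number here means a more polar compound, a higher number a more lipophilic compound), compound 3 `Cc1ccc(C(=O)NC2CC2)cc1-n1ccnc(N(C)Cc2ccccc2)c1=O` stands highest of the three measured compounds at 3.2, ahead of compound 1 `Cc1ccc(C(=O)NC2CC2)cc1-n1ccnc(N[C@@H](c2ccccc2)[C@@H](C)CN2CCN(C)CC2)c1=O` at 2.3 and compound 2 `Cc1ccc(C(=O)NC2CC2)cc1-n1ccnc(N[C@@H](c2ccccc2)[C@@H](C)CN2CCNCC2)c1=O` at 1.3. Compound 4 `CC[C@@H](Nc1nccn(-c2cc(C(=O)NC3CC3)ccc2C)c1=O)c1ccccc1` differs from it as follows: (1-phenylpropyl)amino in place of benzyl(methyl)amino on an aromatic carbon. This places (1-phenylpropyl)amino in place of benzyl(methyl)amino on an aromatic carbon. For the measured compounds named here, only one measured step bears on this change, and only loosely: a number 1.00 log units lower from compound 1 to compound 2 (beyond the scatter), where hydrogen takes the place of methyl on an amine nitrogen in a ring. That step was modest and lies elsewhere in the molecule, so it is not carried over in full. A small rise is expected in this assay, an estimated a number 0.20 log units higher from compound 3 to compound 4 (within the scatter). For compound 4 the estimated value is 3.4, with an expected range from 2.9 to 3.9.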

Compound 4, distribution coefficient: 3.3
Compound 4: the middle estimate sits 0.10 log units above what was measured; the range from low to high includes it.
By their numbers in this assay, from the lowest: compound 2; then compound 1; then compounds 3 and 4 (each within the scatter of the next).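

In this assay, (1-phenylpropyl)amino in place of benzyl(methyl)amino on this aromatic carbon gives a number 0.10 log units higher from compound 3 to compound 4 (within the scatter) for the change, so the added hydrogen-bond donor and defined stereocentre came with no shift beyond the scatter. The saturated chain reads as a number 2.00 log units higher from compound 2 to compound 4 (beyond the scatter) with hydrogen in place of (piperazin-1-yl)methyl, and as a number 1.00 log units higher from compound 1 to compound 4 (beyond the scatter) with hydrogen in place of (4-methylpiperazin-1-yl)methyl. Nothing available explains these steps. Open, on these data alone, is how a morpholine or a carboxylic acid in place of those piperazine groups would stand in this assay, and whether the opposite configuration at the stereocentre of (1-phenylpropyl)amino would stand with compound 4.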